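The source may hold more compounds than are shown below. What is called first, only, known or untested is meant among the compounds shown, and "the series" means these compounds.

Of the compounds shown here, three have so far been measured in an ADME assay on MDCK cells (Canis lupus familiaris) for cytotoxicity; on this read-out lower numbers stand for higher toxicity in this test and higher numbers for lower toxicity in this test. Compound 1 `CSc1nc2n(n1)C(c1ccc(O)c(O)c1)C([N+](=O)[O-])=NN2` gives 362000 nM in this assay. Compound 3 `CSc1nc2n(n1)C(c1ccc(O)c(O)c1O)C([N+](=O)[O-])=NN2` carries hydroxy in place of hydrogen on an aromatic carbon and gives 196000 nM, so that the step of a 1.8-fold lower number from compound 1 to compound 3 (0.27 log units; within the scatter). Compound 2 `O=[N+]([O-])C1=NNc2ncnn2C1c1ccc(O)cc1O` stands on a different core; the difference between the two cores is not broken down here. In this assay compound 2 gives 90000 nM, the lowest of the three numbers, and its distance to both compound 3 and compound 1 lies beyond the scatter.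

Compound 4 `O=[N+]([O-])C1=NNc2ncnn2C1c1c(O)cc(O)cc1O` has not yet been measured. It differs from compound 2 by hydroxy in place of hydrogen on an aromatic carbon. Among the compounds with values here, this is the same kind of change as the one between compound 1 and compound 3, though the surroundings are not identical: in compound 3 the entering group sits ortho to a hydroxy group (1 heavy atom), ortho to a large group and meta to a hydroxy group (1 heavy atom), whereas in compound 4 it sits ortho to a large group and meta to two hydroxy groups (1 heavy atom each). The step from compound 2 to compound 4 is expected to be modest, a 1.5-fold lower number from compound 2 to compound 4 (0.18 log units; within the scatter). Within the data shown here, that expectation rests on the single measured instance of this kind of change, which gave a 1.8-fold lower number from compound 1 to compound 3 (0.27 log units; within the scatter), a step within the scatter. Compound 4 is therefore estimated to give about 60000 nM in this assay, with an expected range from 25000 nM to 150000 nM.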

Compound 4, half-maximal cytotoxic concentration: 119000 nM
Estimate against measurement, compound 4: 2.0-fold (0.30 log units) below; the range from low to high includes it.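

In this assay, within the data shown here, hydroxy in place of hydrogen on an aromatic carbon gives a 1.3-fold higher number from compound 2 to compound 4 (0.12 log units; within the scatter), so on the core of compound 2 the change leaves no step that stands out from repeated measurement. Set beside the earlier step, the two cores cannot be told apart for this change, even though the two steps point in opposite directions: the same change on two cores in this assay, a 1.8-fold lower number (0.27 log units; within the scatter) from compound 1 to compound 3 and a 1.3-fold higher number (0.12 log units; within the scatter) from compound 2 to compound 4, 2.4-fold (0.39 log units) apart, within the scatter of two such steps. Among these compounds, this agrees with the change carrying over from one core to the other without a detectable difference, but it does not show that the change has no effect on either core or that the two cores respond alike, since it rests on only two pairs of compounds, each with a step within the scatter and with the entering hydroxy in different surroundings.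

All the compounds shown carry hydroxy groups on the aromatic ring and a nitro group on the core, so it remains open how this assay would respond if a hydroxy group gave way to a methoxy group or a fluorine atom. Going by these compounds, it also remains open whether an amine or a carboxylic acid in place of the nitro group would produce a step beyond the scatter.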